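Changing the Aryl Group on the Ring Nitrogen of Compound 3

The compounds below may be only part of what the source reports. "The series", "measured", "known", "first", "only" and "open" are said of these compounds alone.

The three measured compounds, all tested in a functional assay on DU-145 cells (Homo sapiens) for cytotoxicity, read by sulforhodamine B assay, with a stated time of 48 h; a higher number here means a weaker inhibitor of growth, a lower number a stronger inhibitor of growth:

Compound 1 `N#Cc1ccc(Nc2nc(Oc3ccnc4ccccc34)nc(N3CCN(c4ccccc4Cl)CC3)n2)cc1C(F)(F)F`: 92600 nM
Compound 2 `N#Cc1ccc(Nc2nc(Oc3ccnc4ccccc34)nc(N3CCN(c4ccccn4)CC3)n2)cc1C(F)(F)F`: 85900 nM
Compound 3 `N#Cc1ccc(Nc2nc(Oc3ccnc4ccccc34)nc(N3CCN(c4cccc(Cl)c4Cl)CC3)n2)cc1C(F)(F)F`: > 100000 nM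

Compound 3 carries only a limit in this assay, (the limit of > 100000 nM in this assay, at which 1 of the 3 values shown sits), so its value is a floor of what the assay reports and not a measured number. The steps that lead to it, an at least 1.0-fold higher number from compound 1 to compound 3 (0.03 log units; that floor lies within the scatter) and an at least 1.1-fold higher number from compound 2 to compound 3 (0.06 log units; that floor lies within the scatter), are both so small that the three compounds cannot be told apart on the numbers shown.

Compound 4 `N#Cc1ccc(Nc2nc(Oc3ccnc4ccccc34)nc(N3CCN(c4cccc(C(F)(F)F)c4)CC3)n2)cc1C(F)(F)F` is the next compound in this series. It differs from compound 3 in one place: 3-(trifluoromethyl)phenyl in place of 2,3-dichlorophenyl on an amine nitrogen in a ring. Going by the values given here, the steps that bear on this kind of change are those that alter the group on the amine nitrogen in the ring: a 1.1-fold lower number from compound 1 to compound 2 (0.03 log units; within the scatter), an at least 1.0-fold higher number from compound 1 to compound 3 (0.03 log units; that floor lies within the scatter) and an at least 1.1-fold higher number from compound 2 to compound 3 (0.06 log units; that floor lies within the scatter). None of them moved the number beyond the scatter, whether the group carried a chloro, two chloro groups, or a pyridin-2-yl.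

The expected step is therefore none beyond the scatter, a number no higher from compound 3 to compound 4 (the limit leaves the size open), with a fair chance that compound 4 is again reported only as a limit. The estimate for compound 4 in this assay is 100000 nM, expected to fall between 45000 nM and 220000 nM.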

Compound 4, concentration for 50% growth inhibition: 38700 nM
Estimate against measurement, compound 4: 2.6-fold (0.41 log units) above, and the stated range ends above it.
By their numbers in this assay, from the lowest: compound 4; then compounds 2 and 1 (each within the scatter of the next). At a limit, above all of these: compound 3.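

In this assay, the group on the amine nitrogen in the ring can move the number beyond the scatter after all: with 3-(trifluoromethyl)phenyl in that place, the steps are a 2.2-fold lower number from compound 2 to compound 4 (0.35 log units; beyond the scatter) and a 2.4-fold lower number from compound 1 to compound 4 (0.38 log units; beyond the scatter), both modest. The third step, an at least 2.5-fold lower number from compound 3 to compound 4 (0.41 log units; beyond the scatter), gives only the smallest size the change can have, and compound 3 is reported only as a limit: the limit of > 100000 nM in this assay, at which 1 of the 4 values shown sits. Among the four compounds shown, only compound 4 stands apart, while compound 1, compound 2 and compound 3 could not be told apart, yet compound 4 at 38700 nM still needs a far from small concentration to inhibit growth.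

The compounds shown do not separate the trifluoromethyl group itself from the spot it occupies on the phenyl ring, since the chloro groups of compound 1 and compound 3 sit differently, and they give no reason for the step. Going by these compounds, it also stays open whether a methyl or a methoxy group in place of the trifluoromethyl would give a similar number, or whether the lower number belongs to trifluoromethyl alone.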